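This account rests on a few compounds, and the source may have more. Where it says the series, first, only, none or still open, it means among the compounds named here.

Measured compounds in a functional assay on HeLa cells (Homo sapiens) for cytotoxicity, with a stated time of 72 h; a higher number here means a weaker inhibitor, a lower number a stronger inhibitor:
compound 1 `Cc1ccc(-c2nc3sc(Cc4ccc(Cl)cc4)nn3c2C=O)cc1`: 21000 nM
compound 2 `O=Cc1c(-c2cc3ccccc3oc2=O)nc2sc(Cc3ccc(Cl)cc3)nn12`: 900 nM
compound 3 `Cc1ccc(-c2nc3sc(Cc4ccc(Cl)cc4)nn3c2SC#N)cc1`: 22000 nM

Compound 2 stands lowest of the three, and its distance to compound 1 and to compound 3 lies beyond the scatter in each case. The difference between the core of compound 1 and the core of compound 2 is not broken down here. From compound 1 to compound 3 the change is cyanosulfanyl in place of formyl on an aromatic carbon, and it gave a 1.0-fold higher number from compound 1 to compound 3 (0.02 log units; within the scatter). Compound 4 `N#CSc1c(-c2cc3ccccc3oc2=O)nc2sc(Cc3ccc(Cl)cc3)nn12` carries the same kind of change from compound 2, (cyanosulfanyl in place of formyl on an aromatic carbon); the place is described once as next to the ring atom that bears a 4-methylphenyl group and once as next to the ring atom that bears a large group. Since the step from compound 1 to compound 3 stayed within the scatter, compound 4 is expected to show a step of a 1.1-fold higher number from compound 2 to compound 4 (0.05 log units; within the scatter). Compound 4 is estimated at 1000 nM, between 400 nM and 2500 nM.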

Compound 4, half-maximal inhibitory concentration: 1000 nM
Estimate against measurement, compound 4: no gap at the digits printed, and the stated range covers the measured number.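

In this assay the step from formyl to cyanosulfanyl on an aromatic carbon stayed within the scatter on the core of compound 2 as well (a 1.1-fold higher number from compound 2 to compound 4 (0.05 log units; within the scatter)). Set beside the earlier step, the change carried from one core to the other with no difference beyond the scatter: the same change on two cores in this assay, a 1.0-fold higher number (0.02 log units; within the scatter) from compound 1 to compound 3 and a 1.1-fold higher number (0.05 log units; within the scatter) from compound 2 to compound 4, 1.1-fold (0.03 log units) apart, within the scatter of two such steps. This rests on two pairs in one assay, so it does not show that the change would carry to any other core, nor why the two groups give matching numbers.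

The compounds shown leave open whether an amine, a carboxylic acid or a longer chain on that aromatic carbon would also leave the number unchanged.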